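The compounds below may be only part of what the source reports. "The series", "measured", "known", "first", "only" and "open" are said of these compounds alone.

Notes on the series. In an ADME assay on MDCK-II cells (Canis lupus familiaris) for permeability (on this read-out higher numbers stand for higher permeability and lower numbers for lower permeability), compound 2 `Cc1ccc(C(=O)NCc2cn(C)nn2)cc1S(=O)(=O)Nc1ccc(-c2ccno2)cc1` gives 12 10^-6 cm/s; compound 1 `Cc1noc(CNC(=O)c2ccc(C)c(S(=O)(=O)Nc3ccc(Cl)cc3)c2)n1` gives 19 10^-6 cm/s and compound 3 `Cc1noc(CNC(=O)c2ccc(C)c(S(=O)(=O)Nc3ccc(-c4ccno4)cc3)c2)n1` gives 6 10^-6 cm/s, and compound 2 lies within the scatter of both, so no order among the three can be claimed from its side. Compound 4 `Cc1ccc(C(=O)NCc2cn(C)nn2)cc1S(=O)(=O)Nc1ccc(Cl)cc1` differs from compound 2 by chloro in place of 1,2-oxazol-5-yl on an aromatic carbon. This change runs opposite to the measured 3.2-fold lower number from compound 1 to compound 3 (0.50 log units; beyond the scatter), which lay beyond the scatter; the other measured step, a 2.0-fold lower number from compound 2 to compound 3 (0.30 log units; within the scatter), concerns a different position and lay within the scatter. A rise in this assay on the order of that reversed step is therefore expected, a 2.5-fold higher number from compound 2 to compound 4 (0.40 log units; beyond the scatter). Compound 4 is accordingly estimated at 30 10^-6 cm/s, with a range of 15 10^-6 cm/s to 60 10^-6 cm/s.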

Compound 4, apparent permeability: 19 10^-6 cm/s
For compound 4 the middle estimate is 1.6-fold (0.20 log units) above the measured one, within the range that was stated.
By their numbers in this assay, from the lowest: compounds 3, 2, 1 and 4 (each within the scatter of the next, the first and the last beyond it).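

On the core of compound 2, chloro in place of 1,2-oxazol-5-yl on an aromatic carbon gives a 1.6-fold higher number from compound 2 to compound 4 (0.20 log units; within the scatter) and so does not repeat beyond the scatter the step seen on the other core, yet the two steps agree: the same change on two cores in this assay, a 3.2-fold lower number (0.50 log units; beyond the scatter) from compound 1 to compound 3 and a 1.6-fold lower number (0.20 log units; within the scatter) from compound 4 to compound 2, 2.0-fold (0.30 log units) apart, within the scatter of two such steps.

With chloro on the aromatic carbon, 1-methyl-1H-1,2,3-triazol-4-yl in place of 3-methyl-1,2,4-oxadiazol-5-yl gives no change at the digits printed from compound 1 to compound 4 (within the scatter) and this change stays within the scatter on both cores: the same change on two cores in this assay, a 2.0-fold lower number (0.30 log units; within the scatter) from compound 2 to compound 3 and no change at the digits printed (within the scatter) from compound 4 to compound 1, 2.0-fold (0.30 log units) apart, within the scatter of two such steps.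

On these data alone, whether an amine or a carboxylic acid on this aromatic carbon would give a step beyond the scatter on both cores remains open.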